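The source may hold more compounds than are shown below. What is called first, only, known or untested is meant among the compounds shown, and "the series" means these compounds.

Measured so far in an assay on Sf9 cells for inhibition of Leucine-rich repeat serine/threonine-protein kinase 2 (Homo sapiens), read by TR-FRET, with stated times of 30 min and 2 h; a lower number here means a stronger inhibitor, a higher number a weaker inhibitor:
Compound 1 `O=C(Nc1cccc(F)c1)c1cc(C(F)(F)F)ccc1OCc1ccc(F)cc1`, 31.6 nM
Compound 2 `CN1CCC(c2ccc(OCc3ccccc3)c(C(=O)Nc3ccnnc3)c2)CC1`, 20 nM

Compound 2 and compound 1 sit within the scatter of each other in this assay, so neither can be ranked above the other on these two numbers. Compound 3 `O=C(Nc1ccnnc1)c1cc(N2CCC(CO)CC2)ccc1OCc1ccccc1` has not been measured yet. It differs from compound 2 in one place: 4-(hydroxymethyl)piperidin-1-yl in place of 1-methylpiperidin-4-yl on an aromatic carbon. Going by the values given here, no step between measured compounds bears on this change, so the expected step of a 2.0-fold higher number from compound 2 to compound 3 (0.30 log units; within the scatter) is small, with no direction beyond the scatter. Compound 3 is therefore estimated at 40 nM in this assay, with a range from 10 nM to 160 nM.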

Compound 3, half-maximal inhibitory concentration: 20 nM
Compound 3: middle estimate off by 2.0-fold (0.30 log units), on the high side; the measured number falls inside the stated range.
By their numbers in this assay, from the lowest: compounds 2, 3 and 1 (each within the scatter of the next).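

In this assay, the step of no change at the digits printed from compound 2 to compound 3 (within the scatter) shows that this position, meta to the (pyridazin-4-yl)carbamoyl group and para to the benzyloxy group, tolerates a swap of 1-methylpiperidin-4-yl for 4-(hydroxymethyl)piperidin-1-yl. The ring's point of attachment and its substituent change together, and a hydrogen-bond donor enters, yet the two numbers stay level. Nothing shown here offers an explanation for this. Open, as far as these compounds go, is whether the hydroxymethyl group itself contributes, which an unsubstituted piperidin-1-yl would test. Also open, from the compounds shown here alone, is how a morpholine or a carboxylic acid would fare at this position.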